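Thiophene replaces methyl on the sulfonyl of compound 3

This account rests on a few compounds, and the source may have more. Where it says the series, first, only, none or still open, it means among the compounds named here.

Compound 1 `Cc1ccc(-c2c(C)cccc2C(=O)Nc2ccc3c(c2)CC(NS(=O)(=O)c2ccccc2)C3)cc1` gives 2.5 nM in an assay for inhibition of apolipoprotein B-100 (Homo sapiens), tested at 100 nM; on this read-out higher numbers stand for weaker inhibition and lower numbers for stronger inhibition.
Compound 2 `Cc1cccc(C(=O)Nc2ccc3c(c2)CC(NS(=O)(=O)c2ccccc2)C3)c1-c1ccc(C#N)cc1` gives 5.5 nM in this assay.
Compound 3 `Cc1cccc(C(=O)Nc2ccc3c(c2)CC(NS(C)(=O)=O)C3)c1-c1ccc(Cl)cc1` gives 6.6 nM in this assay.

Compound 3 stands at the highest of the three numbers in this assay; its gap to compound 2 lies within the scatter, while its gap to compound 1 lies beyond it. Compound 4 `Cc1cccc(C(=O)Nc2ccc3c(c2)CC(NS(=O)(=O)c2cccs2)C3)c1-c1ccc(Cl)cc1` is compound 3 with one change: thiophen-2-yl in place of methyl on a sulfonyl sulfur. Within the data shown here, the single measured step, a 2.2-fold higher number from compound 1 to compound 2 (0.34 log units; beyond the scatter), concerns a different place, a substituent on the aryl ring, and so says nothing directly about a change on the sulfonyl. Among the measured compounds shown here, compounds 1 and 2, which carry an aromatic ring on that sulfonyl sulfur, show lower numbers than compound 3, but each also differs from compound 3 elsewhere, so no clean step exists for this change. An aromatic ring on the sulfonyl is therefore expected to move the number slightly down or leave it where it is, with wide uncertainty. Compound 4 is expected to give 4 nM in this assay, in the range 1.5 nM to 12 nM, which would mean an expected step of a 1.7-fold lower number from compound 3 to compound 4 (0.22 log units; within the scatter).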

Compound 4, half-maximal inhibitory concentration: 3 nM
Compound 4: middle estimate off by 1.3-fold (0.12 log units), on the high side; low and high end bracket the measured number.
By their numbers in this assay, from the lowest: compounds 1, 4, 2 and 3 (each within the scatter of the next, the first and the last beyond it).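

In this assay, among these compounds, thiophen-2-yl in place of methyl on the sulfonyl sulfur gives a 2.2-fold lower number from compound 3 to compound 4 (0.34 log units; beyond the scatter) as the first step that isolates this position, since the earlier compounds with a ring here also differ elsewhere. The step shows that this position accepts a group of five heavy atoms, including an aromatic ring, in place of a single carbon, and that the number falls modestly rather than rises. The data offer no measurement that explains why the number moves this way.

A single step cannot separate the effect of the added ring from that of the sulfur within it. On these data alone, whether a pyridine ring, an ethyl group or a longer carbon chain on the same sulfonyl sulfur would move the number in the same direction remains open.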